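The compounds below may be only part of what the source reports. "The series", "measured", "known", "first", "only" and "open" are said of these compounds alone.

Measured so far:
compound 1, `Nc1sc2c(c1C(=O)NCc1ccccc1)CCCCCC2`: 48%
compound 2, `NC(=O)c1c(N)sc2c1CCCCCC2`: 48%

Both were tested in a functional assay on CHO cells for agonist activity at adenosine receptor A1 (Homo sapiens), read by ERK phosphorylation, tested at 3 uM; on this read-out lower numbers stand for a weaker effect and higher numbers for a stronger effect at the one concentration tested. Compound 2 stands level with compound 1 at the digits shown: the step of no change at the digits printed from compound 1 to compound 2 (within the scatter), hydrogen in place of benzyl on an amide-type nitrogen, lies within the scatter. Compound 3, `Nc1sc2c(c1C(=O)c1ccccc1)CCCCCC2`, is not yet measured. It differs from compound 2 by phenyl in place of amino on a carbonyl carbon. Among the measured compounds shown here, only one measured step exists, and it concerns the amide-type nitrogen rather than the carbonyl carbon, so it bears on the new change only loosely; that step was no change at the digits printed from compound 1 to compound 2 (within the scatter). Compound 1 and compound 2 sit at the same level, which gives no direction for the coming change. Compound 3 is therefore estimated at 45%, with a range from 20% to 70%. This amounts to an expected step of a number 3 percentage points lower from compound 2 to compound 3 (within the scatter), with no move beyond the scatter foreseen.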

Compound 3, a percentage reported as activity, at one concentration (the size of the read-out at that concentration, not a potency): 49%
Compound 3: middle estimate off by 4 percentage points, on the low side; the range from low to high includes it.
By their numbers in this assay, from the lowest: compounds 1, 2 and 3 (each within the scatter of the next).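

In this assay, the move from an amide to a ketone, with phenyl replacing amino on the carbonyl carbon, gives a number 1 percentage points higher from compound 2 to compound 3 (within the scatter). The earlier step had changed only the group on the amide-type nitrogen, whereas this one replaces that nitrogen itself, removing its hydrogen-bond donor and bringing in a six-membered aromatic ring, and still leaves the read-out within the scatter. Thus, among these compounds, neither the amide-type nitrogen nor the amino group at this place is needed to keep this level of effect, and no data bear on why the read-out holds.

On these data alone, it remains open whether a carboxylic acid, a methyl ester or a cyclohexyl group on the same carbonyl carbon would hold this level. As far as these compounds go, because each compound was read at one concentration, any differences in potency also remain open.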